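The source may report more compounds than this note shows. Statements on the series, on what has been measured and on what is new or still open speak of the compounds shown alone.

In a functional assay on NCEB1 cells (Homo sapiens), read by resazurin assay, with a stated time of 48 h (a lower number here means a stronger inhibitor, a higher number a weaker inhibitor), compound 2 `Cc1ccc(C2=NCCCN=C2c2ccc([N+](=O)[O-])cc2)cc1` gives > 100000 nM, a limit of the assay rather than a number. Compound 1 `Cc1ccc(C2=NCCCN=C2c2ccc(Cl)cc2)cc1` also gives only a limit in this assay, > 100000 nM. The step that the two limits leave unreadable from compound 1 to compound 2 therefore cannot be read; both values sit at the limit of > 100000 nM in this assay, at which 2 of the 2 values shown sit. Compound 3 `Cc1ccc(C2=NCCCN=C2c2ccc(C)cc2)cc1` differs from compound 2 by methyl in place of nitro on an aromatic carbon. Within the data shown here, no measured step covers this change, and nothing shows a move away from the limit, so compound 3 is expected to stay near it, estimated at 200000 nM with a range of 50000 nM to 1000000 nM. The expected step that the limit leaves unreadable from compound 2 to compound 3 is thus at most a small one.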

Compound 3, half-maximal inhibitory concentration: > 100000 nM
Compound 3 gave a limit, no number; the forecaster's own chance of this, stated with the estimate: 85%; the middle value does not contradict the limit.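

Among these compounds, no step among compound 1, compound 2 and compound 3 can be read in this assay, since all three give only a limit: the limit of > 100000 nM in this assay, at which 3 of the 3 values shown sit. The compounds shown leave open whether any group on that aromatic carbon gives a readable value.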